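This account rests on a few compounds, and the source may have more. Where it says the series, first, only, none or still open, it means among the compounds named here.

Series notes. Compound 3 `CCC(CO)Sc1nc(NCc2ccc(-c3ccccn3)cc2)c2[nH]nc(C(C)C)c2n1` stands second highest of the three numbers in a functional assay on HT cells (Homo sapiens) for antiproliferative activity, read by fluorescence, with a stated time of 72 h (a higher number here means a weaker inhibitor of growth, a lower number a stronger inhibitor of growth), where compound 3 gives 255 nM. Its nearest neighbour is compound 1 `CSc1nc(NCc2ccc(-c3ccccn3)cc2)c2[nH]nc(C(C)C)c2n1`, which in this assay gives 783 nM; the step between them is a 3.1-fold lower number from compound 1 to compound 3 (0.49 log units; beyond the scatter). Furthest is compound 2 `CC(C)c1n[nH]c2c(NCc3ccc(-c4ccccn4)cc3)nc(SC[C@H](O)CN)nc12`, which in this assay gives 63 nM; the steps are a 12-fold lower number from compound 1 to compound 2 (1.09 log units; beyond the scatter) and a 4.0-fold higher number from compound 2 to compound 3 (0.61 log units; beyond the scatter). Compound 4 `CSCCSc1nc(NCc2ccc(-c3ccccn3)cc2)c2[nH]nc(C(C)C)c2n1` is not yet measured; the change from compound 3 is 2-(methylsulfanyl)ethyl in place of 1-(hydroxymethyl)propyl on a sulfur. Within the data shown here, no measured step covers this exact exchange. Because a 3.1-fold lower number from compound 1 to compound 3 (0.49 log units; beyond the scatter) and a 12-fold lower number from compound 1 to compound 2 (1.09 log units; beyond the scatter) both came with groups bearing a hydrogen-bond donor, while the entering group has none, compound 4 is expected to show a 2.0-fold higher number from compound 3 to compound 4 (0.29 log units; within the scatter), a modest move back toward compound 1. Compound 4 is estimated at 500 nM, range 200 nM to 1500 nM.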

Compound 4, concentration for 50% growth inhibition: 975 nM
The estimate for compound 4 lay 2.0-fold (0.29 log units) below the measured number, and the stated range covers the measured number.
By their numbers in this assay, from the lowest: compound 2; then compound 3; then compounds 1 and 4 (each within the scatter of the next).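

In this assay, a chain on the sulfur gives no gain by itself: with 2-(methylsulfanyl)ethyl, which has no hydrogen-bond donor, the result is a 1.2-fold higher number from compound 1 to compound 4 (0.10 log units; within the scatter). The two chains bearing donors both stay ahead of it, with a 3.8-fold higher number from compound 3 to compound 4 (0.58 log units; beyond the scatter) and a 15-fold higher number from compound 2 to compound 4 (1.19 log units; beyond the scatter). No measurement shown accounts for these steps. Still open, from the compounds shown here alone, is whether the hydroxyl or the amine of compound 2 matters more, which a 2-hydroxyethyl or 2-aminoethyl chain on the sulfur would separate.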